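A few compounds are considered here, and "the series" means these few. Any claim that something is new, unique, unknown or untested is made for them only; others in the source may bear on it.

Measured in a toxicity assay on THP-1 cells (Homo sapiens) for inhibition (on this read-out higher numbers stand for lower toxicity in this test and lower numbers for higher toxicity in this test), so far:
- Compound 1 (`COc1ccc(-c2cnc(NC(=O)c3cccnc3)n2C)cc1`) gives > 100000 nM as a limit.
- Compound 2 (`COc1ccc(-c2cnc(NC(=O)c3ccco3)n2C)cc1`) gives > 100000 nM as a limit.
- Compound 3 (`COc1ccc(-c2cnc(NC(=O)c3ccc(O)cc3)n2C)cc1`) gives > 100000 nM as a limit.

Compound 3 thus has no exact number, and its position is shared with the others: the limit of > 100000 nM in this assay, at which 3 of the 3 values shown sit, sets the picture. Compound 4 (`COc1ccc(-c2cnc(NC(=O)c3ccccc3F)n2C)cc1`) carries 2-fluorophenyl in place of 4-hydroxyphenyl on a carbonyl carbon. Three measured steps change this same place: a step that the two limits leave unreadable from compound 1 to compound 2, a step that the two limits leave unreadable from compound 1 to compound 3 and a step that the two limits leave unreadable from compound 2 to compound 3 give no size. No step beyond the scatter is therefore expected in this assay, and no direction is favoured. The expected step is a number no higher from compound 3 to compound 4 (the limit leaves the size open) as an estimate. The estimate for compound 4 is 100000 nM within an expected range of 40000 nM to 200000 nM in this read-out.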

Compound 4, half-maximal cytotoxic concentration: > 100000 nM
Compound 4: no number, only a limit (the forecaster's own chance of this, stated with the estimate: 85%); the middle value sits exactly at the limit.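

No step can be read between compound 4 and compounds 1, 2 or 3, because each value is only a limit: the limit of > 100000 nM in this assay, at which 4 of the 4 values shown sit. The compounds shown leave open how large the actual values in this assay are and whether any group at this place changes them.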